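Nitrofuran amide after two amides at the limit

The compounds below may be only part of what the source reports. "The series", "measured", "known", "first", "only" and "open" are said of these compounds alone.

Compound 1 `COc1ncc(-c2ccc3ncnc(N[C@H]4CCCN(C(=O)c5cccnc5)C4)c3c2)cc1C#N` and compound 2 `COc1ncc(-c2ccc3ncnc(N[C@H]4CCCN(C(=O)C(C)N)C4)c3c2)cc1C#N` share one core and differ only in the group on the carbonyl carbon. In a functional assay on Ramos cells (Homo sapiens) for antiproliferative activity, read by MTT assay (a higher number here means a weaker inhibitor, a lower number a stronger inhibitor), compound 1 gives > 10000 nM as a limit of the assay. Compound 2 gives > 10000 nM as a limit too, so it has no number of its own. Within the data shown here, the only measured step that the two limits leave unreadable from compound 1 to compound 2 has no readable size, and the limit of > 10000 nM in this assay, at which 2 of the 2 values shown sit, is all that bears on the next change.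

Compound 3 `COc1ncc(-c2ccc3ncnc(N[C@H]4CCCN(C(=O)c5coc([N+](=O)[O-])c5)C4)c3c2)cc1C#N` carries the change 5-nitrofuran-3-yl in place of 1-aminoethyl on a carbonyl carbon with 5-nitrofuran-3-yl in place of 1-aminoethyl on a carbonyl carbon. Among the measured compounds shown here, no measured step gives a size for this change in this assay, so only a modest shift towards stronger inhibition is allowed for, and another reading at the limit is expected to be likely. The estimated change is an at least 1.2-fold lower number from compound 2 to compound 3 (0.09 log units; that floor lies within the scatter) on this working basis. For compound 3 the estimated value is 8000 nM within an expected range from 1500 nM to 20000 nM for this reading.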

Compound 3, half-maximal inhibitory concentration: > 10000 nM
Compound 3: only a limit was reported (the forecaster's own chance of this, stated with the estimate: 60%); middle value at least 1.2-fold (0.09 log units) from the limit.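

In this assay no step can be read from compound 1 to compound 3 or from compound 2 to compound 3, as all of these values are limits of the assay: the limit of > 10000 nM in this assay, at which 3 of the 3 values shown sit.

Left open is whether any group on the carbonyl carbon gives a value in this assay that is not a limit.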